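Chlorophenyl position swap repeated on a second core

The source may report more compounds than this note shows. Statements on the series, on what has been measured and on what is new or still open speak of the compounds shown alone.

Measured so far in a functional assay on A549 cells (Homo sapiens) for antiproliferative activity, read by MTT assay, with a stated time of 48 h; a lower number here means a stronger inhibitor, a higher number a weaker inhibitor:
compound 1 `N#CC1=C(N)Oc2c(c3nc4ccccc4nc3c3ccccc23)C12C(=O)N(Cc1cnnn1-c1ccc(Cl)cc1)c1ccccc12` gives > 50000 nM
compound 2 `N#CC1=C(N)Oc2c(c3nc4ccccc4nc3c3ccccc23)C12C(=O)N(Cc1cnnn1-c1ccccc1Cl)c1ccccc12` gives 42600 nM
compound 3 `N#CC1=C(N)Oc2c(N)cc3nc4ccccc4nc3c2C12C(=O)N(Cc1cnnn1-c1ccc(Cl)cc1)c1ccccc12` gives > 50000 nM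

The value of compound 1 is a limit of this assay, not a number. The value of compound 3 is likewise a limit. Only compound 2 returns a number, and it sits close to that limit.

The change from compound 1 to compound 2 is 2-chlorophenyl in place of 4-chlorophenyl on an aromatic nitrogen. The step it made is an at least 1.1-fold lower number from compound 1 to compound 2 (0.06 log units; that floor lies within the scatter), so nothing in this pair can be read as a real shift.

Compound 4 `N#CC1=C(N)Oc2c(N)cc3nc4ccccc4nc3c2C12C(=O)N(Cc1cnnn1-c1ccccc1Cl)c1ccccc12` has not been measured. It carries the same change, (2-chlorophenyl in place of 4-chlorophenyl on an aromatic nitrogen), on the core of compound 3; the place of the change is described in the same words for both pairs, so this is the same change, not merely the same kind. The difference between the two cores, compound 1 against compound 3, is not broken down here.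

Expectation for compound 4 in this assay: the step is expected to be a number no higher from compound 3 to compound 4 (the limit leaves the size open), flat like the earlier one, because the limit of > 50000 nM in this assay, at which 2 of the 3 values shown sit, makes a limit the most probable outcome for compound 4 as well. The estimate for compound 4 is 50000 nM, with a range from 25000 nM to 120000 nM, and it is expected that the assay reports only a limit.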

Compound 4, half-maximal inhibitory concentration: 29800 nM
Beside the measured number, compound 4's estimate is 1.7-fold (0.22 log units) above it; the range from low to high includes it.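

In this assay, the swap to 2-chlorophenyl on the second core gives an at least 1.6-fold lower number from compound 3 to compound 4 (0.22 log units; that floor lies within the scatter). Compound 3 gives > 50000 nM, which is a limit of the assay and not a number. On both cores, then, the 4-chlorophenyl compound stands at a limit while the 2-chlorophenyl compound returns a number, but this does not show a real shift on either core, nor that the change carries the same size from one core to the other: the same change on two cores in this assay, an at least 1.1-fold lower number (0.06 log units; that floor lies within the scatter) from compound 1 to compound 2 and an at least 1.6-fold lower number (0.22 log units; that floor lies within the scatter) from compound 3 to compound 4; the limit leaves it open whether they differ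

Going by these compounds, the true size of each step stays open until compound 1 and compound 3 can be read as numbers rather than limits, and only then can the two cores be compared for this change. Also open, on these data alone, is how this assay responds when the chlorine on the phenyl ring is replaced by another group, such as methoxy or an amine, or when the aromatic nitrogen of the triazole carries an unsubstituted phenyl, on either core.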